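This account rests on a few compounds, and the source may have more. Where it says the series, first, only, none or still open, it means among the compounds named here.

Compound 1 `O=C(NO)c1ccc(NCc2nc(-c3ccccc3)nn2-c2cccc(Cl)c2)cc1`: 62.3%
Compound 2 `Cc1ccc(-c2nc(CNc3ccc(C(=O)NO)cc3)n(-c3ccccc3)n2)cc1`: 62.2%

Of the compounds shown here, two have been measured in an assay on Sf9 cells for inhibition of protein deacetylase HDAC6 (Homo sapiens), read by fluorescence, with a stated time of 40 min, tested at 100 nM; a higher number here means more inhibition at the concentration tested (going by the name of the read-out), a lower number less inhibition. Compound 1 gives 62.3% and compound 2 gives 62.2%; the two numbers differ by less than the usual scatter, so compound 2 stands level with compound 1 rather than above or below it. Compound 3 `O=C(NO)c1ccc(NCc2nc(-c3cccc(Cl)c3)nn2-c2ccccc2)cc1` has not yet been measured. It differs from compound 2 in one place: 3-chlorophenyl in place of 4-methylphenyl on an aromatic carbon. For the measured compounds named here, no step between measured compounds is available to gauge what such a change does, and the two values in hand, taken with a shared core and comparable substitution patterns, give no sign of a large shift in either direction. A step from compound 2 to compound 3 of no more than the scatter is therefore expected, with no preferred direction, as a number 2.2 percentage points lower from compound 2 to compound 3 (within the scatter). Compound 3 is estimated to give 60%, within a range from 45% to 75%.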

Compound 3, a percentage reported as inhibition, at one concentration (the size of the read-out at that concentration, not a potency): 61.2%
Beside the measured number, compound 3's estimate is 1.2 percentage points below it; the range from low to high includes it.
By their numbers in this assay, from the lowest: compounds 3, 2 and 1 (each within the scatter of the next).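

In this assay, for the compounds shown here, the first step at this position reads a number 1 percentage points lower from compound 2 to compound 3 (within the scatter) and so shows that 3-chlorophenyl can take the place of 4-methylphenyl on this aromatic carbon without a change beyond the scatter. The two groups match in what is counted, with 7 heavy atoms each, one six-membered aromatic ring of carbon only and no hydrogen-bond donors or acceptors, so this step covers only an exchange between two such closely matched groups. Nothing available accounts for how little the number moves.

As far as these compounds go, it remains open whether an amine or a carboxylic acid on the aromatic ring at this position would leave the inhibition level. Also open, from the compounds shown here alone, is what a longer alkyl chain in place of the ring would do to the number at this single concentration.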